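Replacing the pentyl end of compound 3

The source may report more compounds than this note shows. Statements on the series, on what has been measured and on what is new or still open speak of the compounds shown alone.

Compound 1 `COc1cc2[nH]c(C)c(Br)c(=O)c2cc1Cl`: 152 10^-6 cm/s
Compound 2 `C=C(CCCCC)c1c(C)[nH]c2cc(OC)c(Cl)cc2c1=O`: 755 10^-6 cm/s
Compound 3 `CCCCC/C=C/c1c(C)[nH]c2cc(OC)c(Cl)cc2c1=O`: 46.3 10^-6 cm/s

All three were measured in an ADME assay for permeability, using PAMPA, at pH 7.4; a higher number here means that the compound crosses the layer faster, a lower number that the compound crosses the layer more slowly. Compound 3 gives the lowest number of the three, and its gaps to compound 1 and compound 2 both lie beyond the scatter. Compound 4 `COc1cc2[nH]c(C)c(/C=C/C(=O)OC(C)(C)C)c(=O)c2cc1Cl` differs from compound 3 in one place: tert-butoxycarbonyl in place of pentyl on a double-bonded chain carbon bound to a double-bonded chain carbon. Among the compounds with values here, no measured step makes this exact change. Within the data shown here, two steps bear on it only indirectly: the modest 3.3-fold lower number from compound 1 to compound 3 (0.52 log units; beyond the scatter) and the large 16-fold lower number from compound 2 to compound 3 (1.21 log units; beyond the scatter). Neither fixes a direction, so no step beyond the scatter is expected, and the estimated change is a 1.5-fold higher number from compound 3 to compound 4 (0.18 log units; within the scatter). The expected value for compound 4 is 70 10^-6 cm/s, with an estimated range from 20 10^-6 cm/s to 250 10^-6 cm/s.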

Compound 4, apparent permeability: 261 10^-6 cm/s
Beside the measured number, compound 4's estimate is 3.7-fold (0.57 log units) below it; measured number above the stated range.
By their numbers in this assay, from the lowest: compound 3; then compounds 1 and 4 (each within the scatter of the next); then compound 2.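

In this assay the step of a 5.6-fold higher number from compound 3 to compound 4 (0.75 log units; beyond the scatter) lies beyond the scatter, and it shows that the group on a double-bonded chain carbon bound to a double-bonded chain carbon can shift this read-out with the rest of compound 3 unchanged. The earlier steps shown here showed only changes on an aromatic carbon. No measurement at hand gives a cause for this step.

The compounds shown leave open whether the step follows the tert-butyl part or the carbonyl of the entering group. A carboxylic acid or a methyl ester in the same place would separate the two.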